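The compounds below may be only part of what the source reports. "The series", "measured", "known", "first", "only" and "open" are said of these compounds alone.

Measured compounds:
- compound 1 `Cc1oc(=O)oc1COC(=O)c1cccc(NC(=O)[C@@H]2C[C@H](SC3=C(C(=O)O)N4C(=O)[C@H]([C@@H](C)O)[C@H]4[C@H]3C)CN2)c1`: > 95% in an ADME assay for metabolic stability, read by LC-MS, with a stated time of 3 h, at pH 6.5, tested at 50 uM; a lower number here means that less of the compound is left, a higher number that more of the compound is left
- compound 2 `C[C@@H](O)[C@H]1C(=O)N2C(C(=O)OCOC(=O)C(C)(C)C)=C(S[C@@H]3CN[C@H](C(=O)Nc4cccc(C(=O)O)c4)C3)[C@H](C)[C@H]12`: > 95%

In this assay compound 1 gives > 95%, a limit of the assay rather than a number. In the same assay compound 2 gives > 95%, again a limit and not a number. Compound 2 therefore stands where every measured value here stands: the limit of > 95% in this assay, at which 2 of the 2 values shown sit. Among the compounds with values here, no step between measured compounds is available, so there is no measured change to lean on.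

Compound 3 `C[C@@H](O)[C@H]1C(=O)N2C(C(=O)OCOC(=O)OC3CCCCC3)=C(S[C@@H]3CN[C@H](C(=O)Nc4cccc(C(=O)O)c4)C3)[C@H](C)[C@H]12` has not yet been measured. It differs from compound 2 in one place: cyclohexyloxy in place of tert-butyl on a carbonyl carbon. Both measured values sit at the limit, so nothing in the data points to a direction for this change; the expectation is for no movement beyond the usual scatter, with the step from compound 2 to compound 3 estimated as a number no higher from compound 2 to compound 3 (the limit leaves the size open). Compound 3 is thus expected to come out near 95%, within a range of 85% to 99%, most likely reported again as a limit.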

Compound 3, percent of the compound remaining: > 95%
Compound 3: only a limit was reported; the forecaster's own chance of this, stated with the estimate: 70%; the middle value lies on the limit itself.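

Compound 3 gives > 95% in this assay, a limit of the assay and not a number. Within the data shown here, compound 2 also sits at a limit, so no step between compound 2 and compound 3 can be read. Still open is how much of each compound truly remains, and whether cyclohexyloxy in place of tert-butyl changes that at all: the limit of > 95% in this assay, at which 3 of the 3 values shown sit.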